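The compounds below may be only part of what the source reports. "The series", "measured", "known", "first", "only" and "open" are said of these compounds alone.

Compound 1 `Cc1c(Cl)cccc1CCCCOc1ccc(C#Cc2cccc3c(CCCC(=O)O)c(C)n(CC(=O)O)c23)cc1` gives 0.22 nM in a functional assay on CHO-K1 cells for antagonist activity at cysteinyl leukotriene receptor 1 (Homo sapiens), read by fluorescence and calcium flux, with stated times of 30 min and 1 h; a higher number here means a weaker inhibitor, a lower number a stronger inhibitor.
Compound 2 `Cc1c(Cl)cccc1CCCCOc1ccc(C#Cc2cccc3c(CCCC(=O)O)c(C)n(CCCCC(=O)O)c23)cc1` gives 56 nM in this assay.

Of these two measurements, compound 2 has the higher number, the weaker inhibition. Going by the values given here, the only measured step, a 250-fold higher number from compound 1 to compound 2 (2.41 log units; beyond the scatter), lengthened the acid chain on the aromatic nitrogen. Compound 3 `Cc1c(Cl)cccc1CCCCOc1ccc(C#Cc2cccc3c(CCC(=O)O)c(C)n(CCCCC(=O)O)c23)cc1` arises from compound 2 by carboxy in place of carboxymethyl on a saturated chain carbon, two bonds along the chain from an aromatic carbon, which shortens the other acid chain, the one running from an aromatic carbon. Among the compounds with values here, no measured step touches that chain, so the large earlier step is only a loose guide; the expected change is modest, its direction uncertain. The estimated value for compound 3 is 100 nM, expected to lie between 20 nM and 500 nM. That corresponds to an expected step of a 1.8-fold higher number from compound 2 to compound 3 (0.25 log units; within the scatter).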

Compound 3, half-maximal inhibitory concentration: 25 nM
Beside the measured number, compound 3's estimate is 4.0-fold (0.60 log units) above it; the range from low to high includes it.
By their numbers in this assay, from the lowest: compound 1; then compound 3; then compound 2.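

In this assay, shortening the acid chain that runs from an aromatic carbon, from 3-carboxypropyl to 2-carboxyethyl, gives a 2.2-fold lower number from compound 2 to compound 3 (0.35 log units; beyond the scatter). A lower number means stronger inhibition, so this chain also affects the result, and here the shorter version does modestly better. No evidence at hand explains this gain. Going by these compounds, whether the same shortening helps when the aromatic nitrogen carries the shorter acid chain of compound 1 remains open. So does the effect of a still shorter carboxymethyl chain, or of an amide in place of this carboxylic acid.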